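Swapping a five-membered ring on the shared core

The compounds below may be only part of what the source reports. "The series", "measured", "known", "first", "only" and "open" are said of these compounds alone.

Compound 2 `c1ccc(-c2nccs2)c(OCC2=NCCN2)c1` is one of two compounds tested in a functional assay with Alpha-1A adrenergic receptor (Homo sapiens) as the target, read by calcium flux (on this read-out lower numbers stand for smaller maximal responses and higher numbers for larger maximal responses), where compound 2 gives 102%; its neighbour compound 1 `c1csc(-c2ccccc2OCC2=NCCN2)c1` gives 101%, and the step of a number 1 percentage points higher from compound 1 to compound 2 (within the scatter) lies within the scatter. Compound 3 `Cc1ccc(-c2ccccc2OCC2=NCCN2)s1` differs from compound 2 in one place: 5-methylthiophen-2-yl in place of 1,3-thiazol-2-yl on an aromatic carbon. Within the data shown here, the only step bearing on this, the ring swap from compound 1 to compound 2, was flat, and nothing measured speaks to the added methyl. The step of a number 2 percentage points lower from compound 2 to compound 3 (within the scatter) is therefore expected to stay within the scatter. Compound 3 is estimated at 100%, between 85% and 115%.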

Compound 3, largest response reached (reported as maximum), in percent of the reference or control that the assay uses: 97%
Compound 3: middle estimate off by 3 percentage points, on the high side, within the range that was stated.
By their numbers in this assay, from the lowest: compounds 3, 1 and 2 (each within the scatter of the next).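

Replacing 1,3-thiazol-2-yl with 5-methylthiophen-2-yl gives, in this assay, a number 5 percentage points lower from compound 2 to compound 3 (within the scatter). Adding a methyl to the thiophen-2-yl ring, a change the earlier pair did not include, gives a number 4 percentage points lower from compound 1 to compound 3 (within the scatter), so at this place neither change moves the maximal response beyond the scatter. No measured evidence bears on this result.

Still open, on these data alone, is whether the response would hold with a larger change on the five-membered ring, such as an amine, a carboxylic acid or a longer chain in place of the methyl.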